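Aryl amide variation on the hexafluoro-carbinol naphthyl core

This account rests on a few compounds, and the source may have more. Where it says the series, first, only, none or still open, it means among the compounds named here.

Three amides of the shared core have been measured in an assay on LtK cells with ATP-sensitive inward rectifier potassium channel 11 (Homo sapiens) as the target; on this read-out higher numbers stand for an effect only at larger amounts of compound and lower numbers for an effect already at smaller amounts. Compound 1 `O=C(Nc1c(C(O)(C(F)(F)F)C(F)(F)F)ccc2ccccc12)C1CC1` gives 751 nM and is the lowest number of the set. Compound 2 `O=C(NCCCCCCCl)Nc1c(C(O)(C(F)(F)F)C(F)(F)F)ccc2ccccc12` gives 4840 nM and compound 3 `Cc1ccccc1C(=O)Nc1c(C(O)(C(F)(F)F)C(F)(F)F)ccc2ccccc12` gives 5550 nM, so compound 3 carries the highest number, with compound 2 within the scatter of it and compound 1 well apart. The two steps from compound 1 are a 6.4-fold higher number from compound 1 to compound 2 (0.81 log units; beyond the scatter) and a 7.4-fold higher number from compound 1 to compound 3 (0.87 log units; beyond the scatter), while a 1.1-fold higher number from compound 2 to compound 3 (0.06 log units; within the scatter) lies within the scatter.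

Compound 4 `O=C(Nc1c(C(O)(C(F)(F)F)C(F)(F)F)ccc2ccccc12)c1ccc(I)cc1` differs from compound 3 by 4-iodophenyl in place of 2-methylphenyl on a carbonyl carbon. Going by the values given here, no measured step changes a substituent on the aromatic ring at the carbonyl carbon, so nothing here speaks directly to this change; the only guide is that compound 2 and compound 3, both larger than cyclopropyl at that position, sit close together. The expectation is therefore a step of a 1.2-fold lower number from compound 3 to compound 4 (0.09 log units; within the scatter), not beyond the scatter. Compound 4 is estimated at 4500 nM, with a range from 1500 nM to 13000 nM.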

Compound 4, half-maximal effective concentration: 154 nM
Compound 4: the middle estimate sits 29-fold (1.47 log units) above what was measured; the measured number lies below the stated range.
By their numbers in this assay, from the lowest: compound 4; then compound 1; then compounds 2 and 3 (each within the scatter of the next).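

At this position on a carbonyl carbon, the aromatic ring alone does not set the read-out: in this assay, 4-iodophenyl in place of 2-methylphenyl gives a 36-fold lower number from compound 3 to compound 4 (1.56 log units; beyond the scatter), although both groups are six-membered aromatic rings of carbon only with no hydrogen-bond donors or acceptors. The 4-iodophenyl amide also stands apart from the other two groups, with a 31-fold lower number from compound 2 to compound 4 (1.50 log units; beyond the scatter) and a 4.9-fold lower number from compound 1 to compound 4 (0.69 log units; beyond the scatter), so an aryl amide, rather than the cyclopropyl amide, now marks the low end of the set. Nothing at hand accounts for the size of these steps.

Since 2-methylphenyl and 4-iodophenyl differ in both the substituent and its ring number, the compounds shown do not separate those two changes. They also leave open how a plain phenyl, or a bromine or a methyl in place of the iodine, would read.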